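Trimming the methoxy from a thiazole-linked HDAC6 inhibitor

This account rests on a few compounds, and the source may have more. Where it says the series, first, only, none or still open, it means among the compounds named here.

Measured compounds in an assay on isolated protein for inhibition of protein deacetylase HDAC6 (Homo sapiens), read by chemiluminescence, with a stated time of 3 h; a higher number here means a weaker inhibitor, a lower number a stronger inhibitor:
- compound 1 `COc1ccc(-c2cnc(NC(=O)CCCCCCNC(=O)C(O)(O)C(F)(F)F)s2)cc1`: 37000 nM
- compound 2 `COc1ccc(NC(=O)CCCCCCNC(=O)C(O)(O)C(F)(F)F)cc1`: 440000 nM
- compound 3 `COc1ccc2sc(NC(=O)CCCCCCNC(=O)C(O)(O)C(F)(F)F)nc2c1`: 100000 nM

Compound 1 has the lowest number of the three, and so is the strongest inhibitor shown; compound 3 sits beyond the scatter above it, and compound 2 further still. Compound 4 `O=C(CCCCCCNC(=O)C(O)(O)C(F)(F)F)Nc1ncc(-c2ccccc2)s1` is not yet measured. It differs from compound 1 in one place: hydrogen in place of methoxy on an aromatic carbon, so the 4-methoxyphenyl of compound 1 becomes a plain phenyl. Among the measured compounds shown here, no measured pair shows this change, so its effect is unknown here. The expected step of a 1.4-fold higher number from compound 1 to compound 4 (0.13 log units; within the scatter) is small and, if anything, toward a weaker inhibitor. Compound 4 is therefore estimated at 50000 nM, within a range from 15000 nM to 160000 nM.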

Compound 4, half-maximal inhibitory concentration: 350000 nM
Beside the measured number, compound 4's estimate is 7.0-fold (0.85 log units) below it; measured number above the stated range.
By their numbers in this assay, from the lowest: compound 1; then compound 3; then compounds 4 and 2 (each within the scatter of the next).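

In this assay, among the compounds shown here, hydrogen in place of methoxy gives a 9.5-fold higher number from compound 1 to compound 4 (0.98 log units; beyond the scatter), the first measured reading of this change. A loss of only 2 heavy atoms at this ring position is enough to leave compound 4 a clearly weaker inhibitor than compound 1, so what sits here matters. Nothing measured here explains why.

From the compounds shown here alone, whether methoxy itself is needed remains open, as does whether any group at this position would serve. An ethoxy, a hydroxyl or a chlorine atom in the same place would begin to answer that.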